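Kinetic solubility notes on compounds 1 to 4

The compounds below may be only part of what the source reports. "The series", "measured", "known", "first", "only" and "open" are said of these compounds alone.

Measured so far in a physicochemical assay for solubility, measured as kinetic solubility, at pH 2; a higher number here means a more soluble compound, a lower number a less soluble compound:
compound 1, `CC(C)C(c1ccc(-c2ccc3cccc(F)c3c2)[nH]c1=O)C1C(=O)NC(=O)N1C`: 13600 nM
compound 2, `CC(C)C(c1ccc(-c2ccc3cccc(F)c3c2)[nH]c1=O)C1SC(=O)NC1=O`: 11300 nM
compound 3, `CC(C)C(CC1NC(=O)NC1=O)c1ccc(-c2ccc3cccc(F)c3c2)[nH]c1=O`: 13000 nM

All three numbers sit close together. Compound 3 is indistinguishable within the scatter from compound 1 (a 1.0-fold lower number from compound 1 to compound 3 (0.02 log units; within the scatter)) and from compound 2 (a 1.2-fold higher number from compound 2 to compound 3 (0.06 log units; within the scatter)), and compound 1 and compound 2 likewise lie within the scatter of each other (a 1.2-fold lower number from compound 1 to compound 2 (0.08 log units; within the scatter)). The shared core has so far tolerated three different five-membered non-aromatic rings with 2 hetero atoms at the saturated chain carbon bound to an aromatic carbon and a saturated chain carbon without any step beyond the scatter.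

Compound 4, `CC(C)C(/C=C1\SC(=O)NC1=O)c1ccc(-c2ccc3cccc(F)c3c2)[nH]c1=O`, is not yet measured. Relative to compound 3 the change is a group of 8 heavy atoms (4 carbon, 1 nitrogen, 2 oxygen, 1 sulfur; one five-membered non-aromatic ring with 2 hetero atoms) in place of a group of 8 heavy atoms (4 carbon, 2 nitrogen, 2 oxygen; one five-membered non-aromatic ring with 2 hetero atoms), on a saturated chain carbon bound to an aromatic carbon and a saturated chain carbon. The entering group carries 3 double bonds outside aromatic rings and 1 hydrogen-bond donor, against 2 double bonds and 2 donors in the leaving group. The step from compound 3 to compound 2 is the nearest measured comparison, since it also exchanges the 2,5-dioxoimidazolidin-4-yl ring for a sulfur-containing ring, and it stayed within the scatter. Among the compounds with values here, no measured step covers the added double bond outside aromatic rings, so the expectation for compound 4 is a small decrease, estimated as a 1.9-fold lower number from compound 3 to compound 4 (0.27 log units; within the scatter). In this assay compound 4 is expected to give about 7000 nM, within 2500 nM to 18000 nM.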

Compound 4, solubility: 4800 nM
Compound 4: middle estimate off by 1.5-fold (0.16 log units), on the high side; low and high end bracket the measured number.
By their numbers in this assay, from the lowest: compound 4; then compounds 2, 3 and 1 (each within the scatter of the next).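

In this assay, the place on a saturated chain carbon bound to an aromatic carbon and a saturated chain carbon had held every earlier exchange within the scatter, but the group entering in compound 4 gives steps beyond it from all three other compounds (a 2.7-fold lower number from compound 3 to compound 4 (0.43 log units; beyond the scatter)) and (a 2.4-fold lower number from compound 2 to compound 4 (0.37 log units; beyond the scatter)) and (a 2.8-fold lower number from compound 1 to compound 4 (0.45 log units; beyond the scatter)), each of modest size. The sulfur-containing ring of compound 2 stayed within the scatter of the ring in compound 3 (a 1.2-fold higher number from compound 2 to compound 3 (0.06 log units; within the scatter)), whereas the entering group of compound 4, with its sulfur-containing ring and 3 double bonds outside aromatic rings, does not, so in these four compounds a sulfur-containing ring alone does not go with a lower number. Nothing available bears on the reason for this result.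

As far as these compounds go, a (2,4-dioxo-1,3-thiazolidin-5-yl)methyl group at this place would separate the double bond from the longer link, and how it would read in this assay remains open. Also open, from the compounds shown here alone, is whether a carboxylic acid or an amine at this place would stay with compounds 1, 2 and 3 or fall nearer compound 4.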